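This account rests on a few compounds, and the source may have more. Where it says the series, first, only, none or still open, it means among the compounds named here.

Measured so far in a functional assay on CCRF-CEM cells (Homo sapiens) for inhibition; on this read-out lower numbers stand for higher toxicity in this test and higher numbers for lower toxicity in this test:
- compound 1 `O=C1c2ccccc2N(Cc2ccccc2Cl)S(=O)(=O)N1Cc1ccccc1Cl`: 40400 nM
- compound 2 `O=C1c2ccccc2N(Cc2ccccc2)S(=O)(=O)N1Cc1ccc(Cl)cc1`: 27800 nM
- compound 3 `O=C1c2ccccc2N(Cc2ccc(Cl)c(Cl)c2)S(=O)(=O)N1Cc1ccccc1`: 16400 nM

Compound 3 sits at the low end of these three numbers. Compound 1 lies beyond the usual scatter from it, while compound 2 is close enough that the two cannot be told apart. Compound 4 `O=C1c2ccccc2N(Cc2cccc(Cl)c2)S(=O)(=O)N1Cc1ccccc1` has not yet been tested. Going from compound 3 to compound 4 the structure changes in one place: hydrogen in place of chloro on an aromatic carbon. Among the measured compounds shown here, no pair of measured compounds differs in just one place, so no measured step shows what removing one chloro does here. Because compound 2 gives 27800 nM and compound 3 gives 16400 nM, a small shift toward a somewhat higher number is expected for compound 4, probably not beyond the scatter. Compound 4 is estimated at 23000 nM, in the range 11000 nM to 48000 nM, a step of a 1.4-fold higher number from compound 3 to compound 4 (0.15 log units; within the scatter).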

Compound 4, half-maximal cytotoxic concentration: 2100000 nM
Estimate against measurement, compound 4: 91-fold (1.96 log units) below, outside the stated range (above it).
By their numbers in this assay, from the lowest: compounds 3, 2 and 1 (each within the scatter of the next, the first and the last beyond it); then compound 4.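

In this assay, replacing one chloro with hydrogen, which turns the 3,4-dichlorobenzyl group into 3-chlorobenzyl, gives a 130-fold higher number from compound 3 to compound 4 (2.11 log units; beyond the scatter) and so far lower toxicity in this test. Among the compounds shown here, this is the first change in a single place, and it shows that the chloro para to a large group matters greatly here. Losing this one heavy atom counts for far more than the similar numbers of the earlier compounds could suggest.

Going by these compounds, whether a methyl group, a methoxy group or an amine at this position would keep the number low remains open. Nothing available explains why this step is so large.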